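This account rests on a few compounds, and the source may have more. Where it says the series, first, only, none or still open, it means among the compounds named here.

Of the compounds shown here, three of the shared core have been measured in a functional assay on A549 cells (Homo sapiens) for cytotoxicity, read by MTT assay, with a stated time of 48 h; a higher number here means a weaker inhibitor, a lower number a stronger inhibitor. Compound 1 `CCOC(=O)c1c(-c2c(Cl)c3ccccc3oc2=O)nn(-c2ccccc2)c1C(=O)OCC` gives 34000 nM. Compound 2 `CCOC(=O)c1c(-c2cc3ccccc3oc2=O)nn(-c2cccc(C)c2)c1C(=O)OCC` gives 52000 nM. Compound 3 `CCOC(=O)c1c(-c2cc3ccccc3oc2=O)nn(-c2ccc(C)c(C)c2)c1C(=O)OCC` gives 52000 nM, level with compound 2 at the digits shown, the two together the highest of the three numbers, while compound 1 stands within the scatter of compound 3. For the measured compounds named here, the one measured single-point step, no change at the digits printed from compound 2 to compound 3 (within the scatter), was flat. Compound 4 `CCOC(=O)c1c(-c2cc3ccccc3oc2=O)nn(-c2cccc(F)c2)c1C(=O)OCC` differs from compound 3 by 3-fluorophenyl in place of 3,4-dimethylphenyl on an aromatic nitrogen. That change alters the same aryl group on the aromatic nitrogen that the flat step touched, so no shift beyond the scatter is expected. Compound 4 is estimated at 50000 nM, range 25000 nM to 100000 nM. The expected step is a 1.0-fold lower number from compound 3 to compound 4 (0.02 log units; within the scatter).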

Compound 4, half-maximal inhibitory concentration: 59000 nM
Beside the measured number, compound 4's estimate is 1.2-fold (0.07 log units) below it; measured number inside the range.
By their numbers in this assay, from the lowest: compounds 1, 2, 3 and 4 (each within the scatter of the next).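

In this assay there is a 1.1-fold higher number from compound 3 to compound 4 (0.05 log units; within the scatter) for 3-fluorophenyl in place of 3,4-dimethylphenyl on the aromatic nitrogen, and a 1.1-fold higher number from compound 2 to compound 4 (0.05 log units; within the scatter) for fluoro in place of methyl on an aromatic carbon. The earlier step covered only an added methyl, whereas this aryl group now also tolerates fluoro in place of methyl with no shift beyond the scatter. No measured evidence on hand bears on this result. Open, from the compounds shown here alone, is whether an amine or a carboxylic acid on this aryl ring, or a longer chain in its place, would shift the number beyond the scatter.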